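The source may report more compounds than this note shows. Statements on the series, on what has been measured and on what is new or still open speak of the compounds shown alone.

Measured compounds in a functional assay on NCI-H520 cells (Homo sapiens) for inhibition, read by MTT assay, with a stated time of 48 h, tested at 10 uM; on this read-out lower numbers stand for less inhibition and higher numbers for more inhibition at the one concentration tested (going by the name of the read-out):
- compound 1 `Cc1ccc(Nc2cc(NC(=O)Nc3c(Cl)cccc3Cl)ncn2)cc1C` gives 47.5%
- compound 2 `COc1ccc(Br)cc1Nc1cc(NC(=O)Nc2c(Cl)cccc2Cl)ncn1` gives 45%
- compound 3 `COc1ccc(Nc2cc(NC(=O)Nc3c(Cl)cccc3Cl)ncn2)cc1C` gives 29.1%

Compound 3 stands lowest of the three numbers. Its nearest neighbour is compound 2 (a number 15.9 percentage points lower from compound 2 to compound 3 (beyond the scatter)), its furthest is compound 1 (a number 18.4 percentage points lower from compound 1 to compound 3 (beyond the scatter)). Compounds 1 and 2 sit within the scatter of each other (a number 2.5 percentage points lower from compound 1 to compound 2 (within the scatter)), so between those two no order can be read.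

Compound 4 `CCc1ccc(Nc2cc(NC(=O)Nc3c(Cl)cccc3Cl)ncn2)cc1` remains to be measured in this assay. The change from compound 3 is 4-ethylphenyl in place of 4-methoxy-3-methylphenyl on a nitrogen on an aromatic ring.

Among the compounds with values here, two measured steps bear on this. The step from compound 1 to compound 3 swapped a methyl for a methoxy on the aromatic carbon and cost inhibition (a number 18.4 percentage points lower from compound 1 to compound 3 (beyond the scatter)); compound 4 has no methoxy and carries only alkyl on its ring, as compound 1 does. The step from compound 2 to compound 3 likewise moved downward on arrival at the 4-methoxy-3-methylphenyl group (a number 15.9 percentage points lower from compound 2 to compound 3 (beyond the scatter)). Leaving that group is therefore expected to recover inhibition, though 4-ethylphenyl matches neither compound 1 nor compound 2 exactly, so the size is uncertain.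

For compound 4 the expected step is a number 12.9 percentage points higher from compound 3 to compound 4 (beyond the scatter). Compound 4 is estimated at 42%, with a range from 28% to 56%.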

Compound 4, a percentage reported as inhibition, at one concentration (the size of the read-out at that concentration, not a potency): 31.5%
Compound 4: middle estimate off by 10.5 percentage points, on the high side; low and high end bracket the measured number.
By their numbers in this assay, from the lowest: compounds 3 and 4 (each within the scatter of the next); then compounds 2 and 1 (each within the scatter of the next).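

Moving from the 4-methoxy-3-methylphenyl group to 4-ethylphenyl on this nitrogen changes little in this assay: the result is a number 2.4 percentage points higher from compound 3 to compound 4 (within the scatter) and gives no order between these two groups. An alkyl-only ring is therefore not enough for the higher level of this small set, since the change to 4-ethylphenyl gives a number 16 percentage points lower from compound 1 to compound 4 (beyond the scatter) and also a number 13.5 percentage points lower from compound 2 to compound 4 (beyond the scatter) while compound 2 keeps a methoxy group on its ring and compound 4 has none, so compound 2 and compound 4 go against any link between loss of methoxy and more inhibition. Nothing at hand accounts for these differences between the groups on the nitrogen.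

The compounds shown leave open whether the gap between the 3,4-dimethylphenyl and 4-ethylphenyl groups follows the ethyl in place of methyl, the second methyl on the ring, or both, a question that 4-ethyl-3-methylphenyl or 4-methylphenyl would address. Also open, on these data alone, is how this nitrogen substituent responds to a longer chain such as propyl, or to a ring bearing a dimethylamino group or a carboxylic acid.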